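Isopropyl in Place of Hydrogen on the Phenyl Ring

This account rests on a few compounds, and the source may have more. Where it says the series, first, only, none or still open, it means among the compounds named here.

Of the compounds shown here, three sharing one core have been tested in a functional assay on MDA-MB-231 cells (Homo sapiens) for cytotoxicity, read by sulforhodamine B assay, tested at 10 uM; a higher number here means more inhibition at the concentration tested (going by the name of the read-out), a lower number less inhibition. Compound 1 `CC(=O)OC[C@H]1O[C@@H](n2cc(-c3cc(-c4ccccc4)no3)c(=O)[nH]c2=O)C[C@@H]1OC(C)=O` gives 95% in this assay. Compound 2 `CC(C)(C)c1ccc(-c2cc(-c3cn([C@H]4C[C@H](O)[C@@H](CO)O4)c(=O)[nH]c3=O)on2)cc1` gives 102%, and compound 3 `CC(=O)OC[C@H]1O[C@@H](n2cc(-c3cn(Cc4ccccc4)nn3)c(=O)[nH]c2=O)C[C@@H]1OC(C)=O` gives 102%. Compound 1 thus has the lowest of the three numbers, but both others lie within the usual scatter of it, so the three cannot be told apart on these data; all three numbers are level with one another at the concentration tested.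

Compound 4 `CC(=O)OC[C@H]1O[C@@H](n2cc(-c3cc(-c4ccc(C(C)C)cc4)no3)c(=O)[nH]c2=O)C[C@@H]1OC(C)=O` has not yet been measured. It differs from compound 1 in one place: isopropyl in place of hydrogen on an aromatic carbon. Compound 2 carries a tert-butyl group on its phenyl ring and gives 102%, a number level with the other two. The step from compound 1 to compound 4 is expected to be small, a number 4 percentage points higher from compound 1 to compound 4 (within the scatter), with no change beyond the scatter in either direction. Compound 4 is therefore estimated to give 99%, in the range from 88% to 106%.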

Compound 4, a percentage reported as inhibition, at one concentration (the size of the read-out at that concentration, not a potency): 83.2%
Compound 4: the middle estimate sits 15.8 percentage points above what was measured, outside the stated range (below it).
By their numbers in this assay, from the lowest: compound 4; then compounds 1, 2 and 3 (each within the scatter of the next).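

For the compounds shown here, the change from phenyl to 4-isopropylphenyl gives a number 11.8 percentage points lower from compound 1 to compound 4 (beyond the scatter) in this assay, and this is the only step that can be read. It shows that the number is not indifferent to what stands on this aromatic carbon, para to a large group, something the three earlier compounds could not show because their numbers were level and none differed from another in one place. Even so, the loss is modest, and compound 4 still gives 83.2% at the concentration tested; nothing at hand explains the drop.

The compounds shown leave open whether the drop belongs to isopropyl itself or would follow any group at this place. A methyl group, an amine or a carboxylic acid on the same carbon of compound 1 would help to separate these possibilities.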